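Urea to amide on a pyrazole series: an expected step

The source may hold more compounds than are shown below. What is called first, only, known or untested is meant among the compounds shown, and "the series" means these compounds.

Measured so far:
- compound 1, `O=C(Nc1cccc(-n2cc(-c3ccncc3)c(-c3cc(O)cc(Cl)c3)n2)c1)Nc1ccc(Cl)c(C(F)(F)F)c1`, gives 98%
- compound 2, `COc1cc(Cl)cc(-c2nn(-c3cccc(NC(=O)Nc4ccc(Cl)c(C(F)(F)F)c4)c3)cc2-c2ccncc2)c1`, gives 98%

Both values come from a functional assay on SK-MEL-5 cells (Homo sapiens) for inhibition, read by sulforhodamine B assay, with a stated time of 48 h, tested at 0.1 uM; a lower number here means a stronger effect, a higher number a weaker effect of the compound at the concentration tested. Compound 1 and compound 2 stand level with each other: the step of no change at the digits printed from compound 1 to compound 2 (within the scatter) lies within the scatter, and the change it covers is a methyl in place of hydrogen on an oxygen on an aromatic ring. Compound 2 therefore shows essentially the same read-out as its nearest neighbour, a number at the high end, meaning little effect at the concentration tested.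

Compound 3, `COc1cc(Cl)cc(-c2nn(-c3cccc(NC(=O)c4cccc(C(F)(F)F)c4)c3)cc2-c2ccncc2)c1`, is the next step. Its change from compound 2 is 3-(trifluoromethyl)phenyl in place of (4-chloro-3-(trifluoromethyl)phenyl)amino on a carbonyl carbon. Within the data shown here, no measured step touches this part of the molecule; the only step recorded concerns the methyl on the oxygen and is flat. With no evidence either way, a step beyond the scatter is not expected: compound 3 is estimated to give 96%, within a range from 84% to 105%, which means an expected step of a number 2 percentage points lower from compound 2 to compound 3 (within the scatter).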

Compound 3, a percentage reported as activity, at one concentration (the size of the read-out at that concentration, not a potency): 95%
For compound 3 the middle estimate is 1 percentage points above the measured one; measured number inside the range.
By their numbers in this assay, from the lowest: compounds 3, 1 and 2 (each within the scatter of the next).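

Among these compounds, the change on the carbonyl carbon is the first in this set to touch this end of the molecule, and in this assay it gives a number 3 percentage points lower from compound 2 to compound 3 (within the scatter) even though it is a large edit. The leaving (4-chloro-3-(trifluoromethyl)phenyl)amino has 12 heavy atoms and 1 hydrogen-bond donor, and the entering 3-(trifluoromethyl)phenyl has 10 heavy atoms and 0 hydrogen-bond donors, so this swap at this position leaves the read-out within the scatter, just as the methyl on the oxygen did at the other end of the molecule. All three compounds still sit at the high end of the scale, which means little effect at the concentration tested, and nothing available explains the flat result.

The swap removes the amide-type nitrogen of the leaving group and its chlorine together, so the compounds shown do not tell what each of these does alone, or whether either would matter at a concentration where the read-out falls. Also open, from the compounds shown here alone, is whether a different group on the carbonyl carbon, such as a piperazine amine or a longer alkyl chain, would bring the number down.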